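A few compounds are considered here, and "the series" means these few. Any claim that something is new, unique, unknown or untested is made for them only; others in the source may bear on it.

In a functional assay on NCI-H460 cells (Homo sapiens) for antiproliferative activity, with a stated time of 72 h (a higher number here means a weaker inhibitor, a lower number a stronger inhibitor), compound 1 `COc1cc(C(=O)c2cnc3ccccc3c2)cc(OC)c1OC` gives 1600 nM while compound 2 `COc1cc(C(=O)c2ccc3ncccc3c2)cc(OC)c1OC` gives 36 nM and compound 3 `COc1cc(C(=O)c2ccnc3c(OC)cccc23)cc(OC)c1OC` gives 193 nM even though the three share much of their structure. Compound 2 thus holds the lowest of the three numbers, which makes it the strongest inhibitor of the group, and its gaps to both others lie beyond the usual scatter.

Compound 4 `COc1ccc2cc(C(=O)c3cc(OC)c(OC)c(OC)c3)ccc2n1` differs from compound 2 by a single change methoxy in place of hydrogen on an aromatic carbon which is methoxy in place of hydrogen on an aromatic carbon, next to the ring nitrogen. Among the measured compounds shown here, no measured pair shows this change on its own, so any expectation rests on indirect evidence. Compound 3 also carries a methoxy on its core and gives 193 nM as its result, but it differs from compound 2 in more than that one group, so it is only a weak guide. The wide spread of the three values also suggests that this series can respond strongly to modest edits. A modest loss of activity is therefore expected, and it may barely clear the scatter. The estimated move is a 1.9-fold higher number from compound 2 to compound 4 (0.29 log units; within the scatter) in the direction of weaker inhibition. For compound 4 the estimated value is 70 nM with an expected range from 18 nM to 300 nM in this measurement.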

Compound 4, half-maximal inhibitory concentration: 257 nM
Compound 4: the middle estimate sits 3.7-fold (0.56 log units) below what was measured; low and high end bracket the measured number.
By their numbers in this assay, from the lowest: compound 2; then compounds 3 and 4 (each within the scatter of the next); then compound 1.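

In this assay, putting methoxy in place of hydrogen on an aromatic carbon, next to the ring nitrogen, gives a 7.1-fold higher number from compound 2 to compound 4 (0.85 log units; beyond the scatter), a move toward weaker inhibition that lies beyond the scatter. Among the compounds shown here, this pair differs in that one place only, so it offers the first direct reading of the change, which compound 3 could not provide with its several differences from compound 2. At this position, then, the swap from hydrogen to methoxy is not neutral: on this core it costs activity, though compound 4 remains a measurable inhibitor. The data on hand offer no explanation for this loss.

The compounds shown hold only hydrogen and methoxy at this carbon, so it remains open whether a smaller group such as fluorine, or a different one such as an amine, would fare better or worse. Going by these compounds, it also remains open whether methoxy would bring a similar loss on the core of compound 1, where the ring nitrogen and the carbonyl link lie differently.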